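Butoxy in place of isobutoxy: notes on compound 3

The source may hold more compounds than are shown below. What is called first, only, known or untested is meant among the compounds shown, and "the series" means these compounds.

Among the measured compounds shown here, in a functional assay on A549 cells (Homo sapiens) for antiproliferative activity, read by sulforhodamine B assay, with a stated time of 3 days (on this read-out lower numbers stand for an effect already at smaller amounts and higher numbers for an effect only at larger amounts of compound), compound 2 `CCCC1=C(OCC(C)C)C(CCC)(CCC)C(=O)/C(=C(O)\C=C\c2ccccc2)C1=O` gives 1.7 uM, the lower of the two numbers so far, and compound 1 `CCCC1=C(OCCC(C)C)C(CCC)(CCC)C(=O)/C(=C(O)\C=C\c2ccccc2)C1=O` gives 11.3 uM. The next compound, compound 3 `CCCCOC1=C(CCC)C(=O)/C(=C(O)/C=C/c2ccccc2)C(=O)C1(CCC)CCC`, differs from compound 2 by propyl in place of isopropyl on a saturated chain carbon bound to an oxygen on an unsaturated carbon, which also reads as isobutoxy to butoxy.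

For the measured compounds named here, only one measured step bears on this place: a 6.6-fold lower number from compound 1 to compound 2 (0.82 log units; beyond the scatter). That step is beyond the scatter, but it is only a loose guide. It replaced isobutyl with isopropyl, whereas the new change keeps the same atoms and joins them differently. The series holds no direct comparison of a branched group with an unbranched one. A move towards higher numbers in this assay is still expected, though a smaller one than the measured step. The expected change is a 2.4-fold higher number from compound 2 to compound 3 (0.37 log units; beyond the scatter). For compound 3 the estimated value is 4 uM, with an expected range of 1.2 uM to 12 uM.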

Compound 3, concentration for half-maximal effect: 7.1 uM
Estimate against measurement, compound 3: 1.8-fold (0.25 log units) below; the range from low to high includes it.
By their numbers in this assay, from the lowest: compound 2; then compounds 3 and 1 (each within the scatter of the next).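

In this assay, joining the same atoms differently is enough to move the number: isobutoxy to butoxy gives a 4.2-fold higher number from compound 2 to compound 3 (0.62 log units; beyond the scatter), so at this place the arrangement of the chain counts, and not only its size. The other new step, a 1.6-fold lower number from compound 1 to compound 3 (0.20 log units; within the scatter), lies within the scatter, so the butoxy group of compound 3 and the longer branched group of compound 1 cannot be told apart in this assay. Among the three compounds, the isobutoxy group of compound 2 alone stands apart, with its steps to both others beyond the scatter, so branching by itself does not mark out the lower number: compound 1 is also branched and does not share it.

No measurement at hand gives a reason for these differences.

The compounds shown leave open how a shorter chain such as ethoxy, a ring-bearing group such as cyclopropylmethoxy, or a chain ending in an amine would read at this place. They also leave open whether the gap between isobutoxy and butoxy persists when the propyl groups elsewhere on the shared core are replaced.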